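A few compounds are considered here, and "the series" means these few. Any claim that something is new, unique, unknown or untested is made for them only; others in the source may bear on it.

Compound 1 `CCCCC(CCO)n1cnc2c(Cl)ncnc21` gives > 50000 nM in a functional assay on SW480 cells (Homo sapiens) for antiproliferative activity, read by MTT assay, with a stated time of 48 h (a higher number here means a weaker inhibitor, a lower number a stronger inhibitor), which is a limit of the assay and not a number.
Compound 2 `CCCCC(CCO)n1cnc2cncnc21` gives > 50000 nM in this assay, again only a limit.
Compound 3 `CCCCCC(CCO)n1cnc2c(Cl)ncnc21` gives > 50000 nM in this assay, again only a limit.

Compound 2 and compound 1 differ by chloro in place of hydrogen on an aromatic carbon. The step that the two limits leave unreadable from compound 2 to compound 1 cannot be sized, since (the limit of > 50000 nM in this assay, at which 3 of the 3 values shown sit). The same holds for a step that the two limits leave unreadable from compound 1 to compound 3, where a methyl replaces hydrogen on a saturated chain carbon, five bonds along the chain from an aromatic nitrogen. The difference between the cores of compound 3 and compound 2 is not broken down here.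

Compound 4 `CCCCCC(CCO)n1cnc2c(Cl)nc(Cl)nc21` has not been measured. It differs from compound 3 by chloro in place of hydrogen on an aromatic carbon. This is the same kind of change as from compound 2 to compound 1, but not the same: in compound 4 the chloro sits between two ring nitrogen atoms, meta to a chloro group, meta to a fused ring and para to a fused ring, whereas in compound 1 it sits next to the ring nitrogen, ortho to a fused ring, meta to a fused ring, opposite the ring nitrogen.

The expected step is a number no higher from compound 3 to compound 4 (the limit leaves the size open). That expectation rests on compound 3, which gives only the limit > 50000 nM, and on the unreadable earlier step. Compound 4 is expected near 50000 nM, within 15000 nM to 150000 nM, most likely again reported only as a limit.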

Compound 4, half-maximal inhibitory concentration: 6010 nM
Estimate against measurement, compound 4: 8.3-fold (0.92 log units) above; the whole stated range lies above it.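

In this assay, placing a chloro between two ring nitrogen atoms gives an at least 8.3-fold lower number from compound 3 to compound 4 (0.92 log units; beyond the scatter). Compound 3 gives > 50000 nM, which is a limit of the assay and not a number, so this step shows that the change matters on the core of compound 3 but gives only a minimum for its size. It does not show that the change carries from one core to another, since the only other chloro step, from compound 2 to compound 1, puts the group at a different place on the ring and, like the methyl step, cannot be read: the limit of > 50000 nM in this assay, at which 3 of the 4 values shown sit.

The compounds shown leave open whether the same chloro would give a similar result with the shorter chain of compound 1, or whether a still longer chain would change the result. They also leave open whether an amine or a methoxy group at this place would do what the chloro does here, so the chloro cannot yet be said to be special.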